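This account rests on a few compounds, and the source may have more. Where it says the series, first, only, none or still open, it means among the compounds named here.

Compound 1 `COc1ccc(-n2c(SCc3ccccc3)nnc2-c2cc(OC)c(OC)c(OC)c2)cc1` and compound 2 `COc1ccc(-n2c(SCc3ccc(F)cc3)nnc2-c2cc(OC)c(OC)c(OC)c2)cc1` share one core and differ only at one aromatic carbon. In a functional assay on PC-3 cells (Homo sapiens) for inhibition, read by MTT assay, with a stated time of 48 h (on this read-out higher numbers stand for weaker inhibition and lower numbers for stronger inhibition), compound 1 gives 34100 nM, and compound 2 gives 35000 nM. For the measured compounds named here, the only measured step, a 1.0-fold higher number from compound 1 to compound 2 (0.01 log units; within the scatter), leaves the two numbers within the scatter of each other, so compound 1 stands alongside compound 2 rather than apart from it. Compound 3 `COc1ccc(-n2c(SCC(=O)Nc3ccc(Cl)cc3)nnc2-c2cc(OC)c(OC)c(OC)c2)cc1` is not yet measured. It differs from compound 1 by (4-chlorophenyl)carbamoyl in place of phenyl on a saturated chain carbon bound to a sulfur. Going by the values given here, no measured step touches this part of the molecule, and the single step that was measured lay within the scatter, so the data give no guide to the size or direction of any change here. Compound 3 is therefore expected to give a number close to that of compound 1, a step of a 1.1-fold lower number from compound 1 to compound 3 (0.06 log units; within the scatter). The estimate for compound 3 in this assay is 30000 nM, with a range from 10000 nM to 90000 nM.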

Compound 3, half-maximal inhibitory concentration: 6290 nM
Beside the measured number, compound 3's estimate is 4.8-fold (0.68 log units) above it; the measured number lies below the stated range.
By their numbers in this assay, from the lowest: compound 3; then compounds 1 and 2 (each within the scatter of the next).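

Replacing the phenyl on a saturated chain carbon bound to a sulfur with (4-chlorophenyl)carbamoyl moves the number clearly in this assay: the change gives a 5.4-fold lower number from compound 1 to compound 3 (0.73 log units; beyond the scatter) and, starting from the 4-fluorophenyl group, a 5.6-fold lower number from compound 2 to compound 3 (0.75 log units; beyond the scatter). The earlier step, fluoro in place of hydrogen on an aromatic carbon, stayed within the scatter, so these compounds give the first sign that inhibition of PC-3 cells responds to a larger change at this position. No measurement shown gives a reason for this shift.

The new group differs from phenyl in both its carbonyl with amide hydrogen and its chlorine, so the compounds shown do not separate what each part contributes. Also open, as far as these compounds go, is how a phenylcarbamoyl group without chlorine, a carboxylic acid or a longer chain would behave at this place.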